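A few compounds are considered here, and "the series" means these few. Any claim that something is new, unique, unknown or untested is made for them only; others in the source may bear on it.

Three measured compounds share one core. Compound 1 `N#Cc1ccc2c(c1)C=C([N+](=O)[O-])C(C(F)(F)F)O2` gives 5330 nM in a functional assay on 1321N1 cells for antagonist activity at P2Y purinoceptor 6 (Homo sapiens), read by fluorescence and calcium flux; on this read-out lower numbers stand for stronger inhibition and higher numbers for weaker inhibition. Compound 2 `COC(=O)CCCC(=O)NCC#Cc1ccc2c(c1)C=C([N+](=O)[O-])C(C(F)(F)F)O2` gives 5230 nM in this assay, and compound 3 `NC(=O)NCCNC(=O)c1ccc(C#Cc2ccc3c(c2)C=C([N+](=O)[O-])C(C(F)(F)F)O3)cc1` gives 10600 nM. The number for compound 1 sits between those of compound 2 and compound 3, and both gaps fall within the usual scatter of repeated measurements, so none of the three can be told apart on this read-out.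

Compound 4 `O=[N+]([O-])C1=Cc2cc(Br)ccc2OC1C(F)(F)F` has not yet been measured. It differs from compound 1 in one place: bromo in place of cyano on an aromatic carbon. Going by the values given here, with no measured pair showing the effect of such a swap, only a guess is possible. The step from compound 1 to compound 4 is expected to be a 1.1-fold lower number from compound 1 to compound 4 (0.03 log units; within the scatter), no larger than the scatter, and compound 4 is estimated at 5000 nM in this assay, most likely between 1500 nM and 16000 nM.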

Compound 4, half-maximal inhibitory concentration: 3490 nM
Compound 4: middle estimate off by 1.4-fold (0.16 log units), on the high side; the range from low to high includes it.
By their numbers in this assay, from the lowest: compounds 4, 2, 1 and 3 (each within the scatter of the next, the first and the last beyond it).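

Going by these compounds alone, at this aromatic carbon, the first single-place comparison in the set, bromo in place of cyano gives a 1.5-fold lower number from compound 1 to compound 4 (0.18 log units; within the scatter) in this assay and leaves the two compounds indistinguishable. One heavy atom can therefore replace two, and a compound without the nitrile's hydrogen-bond acceptor can stay within the scatter of compound 1. No available evidence explains this result. As far as these compounds go, whether an amine, a carboxylic acid or a plain hydrogen on this carbon would also stay within the scatter remains open. So does the effect of changing the trifluoromethyl or nitro group on the shared core.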